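The source may report more compounds than this note shows. Statements on the series, on what has been measured and on what is new or still open speak of the compounds shown alone.

In a functional assay on MCF7 cells (Homo sapiens) for antiproliferative activity (on this read-out higher numbers stand for weaker inhibition and lower numbers for stronger inhibition), compound 1 `CC(C)=CCc1cc(C(=O)Nc2cc3ccc(OCCCN4CCCCC4)c(C)c3oc2=O)ccc1O` gives > 50000 nM, which is a limit of the assay and not a number. Within the data shown here, compound 2 `CC(C)=CCc1cc(C(=O)Nc2cc3ccc(OCCCNCC(C)C)c(C)c3oc2=O)ccc1O` gives 1320 nM, the only true number so far, so it has no measured neighbour to be ranked against. Compound 3 `CC(C)=CCc1cc(C(=O)Nc2cc3ccc(OCCCN(C)C(C)C)c(C)c3oc2=O)ccc1O` differs from it as follows: isopropyl(methyl)amino in place of isobutylamino on a saturated chain carbon, three bonds along the chain from an oxygen on an aromatic ring. Isopropyl(methyl)amino stands in place of isobutylamino on a saturated chain carbon, three bonds along the chain from an oxygen on an aromatic ring. Among the measured compounds shown here, one measured step bears on this, a large one at the same place: an at least 37-fold lower number from compound 1 to compound 2 (1.57 log units; beyond the scatter). There, piperidin-1-yl gave way to isobutylamino, so the group at this spot can matter greatly in this assay. A smaller move towards weaker inhibition is expected here, an estimated 2.7-fold higher number from compound 2 to compound 3 (0.42 log units; beyond the scatter). For compound 3 the estimate is 3500 nM, with an expected range from 900 nM to 20000 nM.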

Compound 3, half-maximal inhibitory concentration: 1050 nM
Estimate against measurement, compound 3: 3.3-fold (0.52 log units) above, within the range that was stated.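

In this assay, replacing isobutylamino with isopropyl(methyl)amino takes the count of hydrogen-bond donors in this group from 1 to 0 and gives a 1.3-fold lower number from compound 2 to compound 3 (0.10 log units; within the scatter), so the donor in the group of compound 2 is not needed to keep this level of activity, at least in this pair. Compared with the ring-bearing piperidin-1-yl group, the second open-chain amine gives an at least 47-fold lower number from compound 1 to compound 3 (1.67 log units; beyond the scatter), so two open-chain amines now stand well apart from the one ring-bearing amine. For compound 1 the reading is a limit of the assay and not a number, so the true size of both large steps stays unknown: the limit of > 50000 nM in this assay, at which 1 of the 3 values shown sits.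

The compounds shown cannot separate the presence of a ring from other differences between these amines. A pyrrolidin-1-yl or morpholin-4-yl group at this place, or a plain dimethylamino group, would help to settle that.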